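The source may report more compounds than this note shows. Statements on the series, on what has been measured and on what is new or still open speak of the compounds shown alone.

Measured so far:
- compound 1, `CC[C@@]1(O)[C@@H](CO)O[C@@H](n2ccc(N)nc2=O)[C@@H]1O`: 258000 nM
- compound 2, `CC#C[C@@]1(O)[C@@H](CO)O[C@@H](n2ccc(=O)[nH]c2=O)[C@@H]1O`: 70800 nM

Both compounds were tested in a functional assay on KB cells (Homo sapiens), read by MTT assay; a lower number here means a stronger inhibitor, a higher number a weaker inhibitor. Compound 1 has the highest number of the two; compound 2 gives the lower number, and the gap between the two values is beyond the usual scatter, so compound 2 is the stronger inhibitor of the pair. Both numbers are very high, which means that neither compound inhibits the cells strongly.

Compound 3, `Nc1ccn([C@@H]2O[C@H](CO)[C@](O)(C3CC3)[C@H]2O)c(=O)n1`, has not yet been measured. It is derived from compound 1 by a single change: cyclopropyl in place of ethyl on a saturated ring carbon. No other part of the shared core is touched. Within the data shown here, no step between two measured compounds is known that would show what such a change does, so the expectation for compound 3 rests only on the value of compound 1 and on the small size of the change.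

In this assay compound 3 is expected to give 200000 nM, within a range from 50000 nM to 700000 nM. The expected step of a 1.3-fold lower number from compound 1 to compound 3 (0.11 log units; within the scatter) is therefore estimated to be small, with no clear direction beyond the scatter.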

Compound 3, half-maximal inhibitory concentration: > 350000 nM
Compound 3 ended at the assay's limit (the forecaster's own chance of this, stated with the estimate: 25%); at least 1.7-fold (0.24 log units) between middle value and limit.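

In this assay compound 3 gives > 350000 nM as a limit of the assay and not as a number, and it is the only compound shown that ends at this limit: the limit of > 350000 nM in this assay, at which 1 of the 3 values shown sits.

Placing cyclopropyl in place of ethyl on this saturated ring carbon gives an at least 1.3-fold higher number from compound 1 to compound 3 (0.13 log units; that floor lies within the scatter) and, since the true value of compound 3 is unknown, the real step may be larger than that floor. This pair gives the first direct view of a change at this position with the rest of the shared core held constant, and it shows that swapping the two-carbon chain for the three-membered ring does not produce a stronger inhibitor in these cells.

As far as these compounds go, how far compound 3 really lies from compound 1 stays open, and compound 2 differs from compound 1 in more than one place, so its lower number cannot be assigned to the group on this carbon alone. Also open, from the compounds shown here alone, is whether a longer chain such as propyl, or an amine carried on that chain, would move the number in either direction at this position.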